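The source may report more compounds than this note shows. Statements on the series, on what has been measured and on what is new or still open speak of the compounds shown alone.

Measured in a functional assay on PC-3 cells (Homo sapiens) for cytotoxicity, read by WST assay, with a stated time of 72 h; a higher number here means a weaker inhibitor, a lower number a stronger inhibitor
- compound 1 `Cc1ccc(C2(c3ccc(O)cc3)C(=O)Nc3c2ccc(F)c3F)cc1` gives 0.8 nM
- compound 2 `CCCOc1ccc(C2(c3ccc(O)cc3)C(=O)Nc3c2ccc(F)c3F)cc1` gives > 1000 nM as a limit of the assay

For the measured compounds named here, compound 1 holds the only true number so far, since the other result is a limit. Compound 3 `O=C1Nc2c(ccc(F)c2F)C1(c1ccc(O)cc1)C1CCCC1` keeps the core of compound 1 and has cyclopentyl in place of 4-methylphenyl on a saturated ring carbon, counted as cyclopentyl in place of 4-methylphenyl on a saturated ring carbon for this change. Going by the values given here, one measured step bears on it, namely an at least 1200-fold higher number from compound 1 to compound 2 (3.09 log units; beyond the scatter) for propoxy in place of methyl on an aromatic carbon, a large step made within that same 4-methylphenyl. That step ends at the limit of > 1000 nM in this assay, at which 1 of the 2 values shown sits, and is itself only a bound. A move to a higher number in this assay is expected, beyond the scatter but smaller than that large step. The expected step is a 50-fold higher number from compound 1 to compound 3 (1.70 log units; beyond the scatter) as a working estimate. For compound 3 the expected value is 40 nM with an estimated range of 4 nM to 500 nM for now.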

Compound 3, half-maximal inhibitory concentration: 8.2 nM
The estimate for compound 3 lay 4.9-fold (0.69 log units) above the measured number; low and high end bracket the measured number.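

In this assay, the 4-methylphenyl on the saturated ring carbon can give way to cyclopentyl, a non-aromatic carbon ring, with a real but bounded cost: a 10-fold higher number from compound 1 to compound 3 (1.01 log units; beyond the scatter). Compound 3 gives 8.2 nM, so activity at this position survives without an aromatic ring here, and the series now has a second true number to read steps against. Compound 2 remains a limit, so its step gives only a bound: the limit of > 1000 nM in this assay, at which 1 of the 3 values shown sits.

The compounds shown do not separate the effect of ring size from that of aromatic character, and cyclohexyl or unsubstituted phenyl at this position would bear on that. Also open, from the compounds shown here alone, is how a longer chain or an amine in place of cyclopentyl would read in this assay.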